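The source may report more compounds than this note shows. Statements on the series, on what has been measured and on what is new or still open speak of the compounds shown alone.

Measured compounds:
compound 1, `CCCc1nc(-c2ccccc2)c(CNCCCN2CCN(c3cccc(OC)c3)CC2)o1`: 36.4%
compound 2, `CCCc1nc(-c2ccccc2)c(CNCCN2CCN(C(c3ccccc3)c3ccccc3)CC2)o1`: 71.9%
compound 3, `CCCc1nc(-c2ccccc2)c(CNCCN2CCN(c3cccc(C)c3C)CC2)o1`: 66.7%

These three compounds share one core and were all tested in an assay on HEK293 cells for inhibition of Voltage-dependent T-type calcium channel subunit alpha-1G (Homo sapiens), read by fluorescence, tested at 10 uM; a higher number here means more inhibition at the concentration tested (going by the name of the read-out), a lower number less inhibition. Compound 1 gives the lowest of the three numbers, 36.4%. Compound 3 is the nearest to it, standing higher by a gap beyond the scatter, and compound 2 stands furthest, also beyond the scatter. Within the data shown here, compound 2 and compound 3 each differ from compound 1 in more than one place, so no single-change step between measured compounds can be read from them.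

Compound 4, `CCCc1nc(-c2ccccc2)c(CNCCCN2CCN(c3cccc(Cl)c3)CC2)o1`, has not yet been measured. It differs from compound 1 in one place: chloro in place of methoxy on an aromatic carbon. Cut one bond further out, this exchange reads as 3-methoxyphenyl becoming 3-chlorophenyl. Among the measured compounds shown here, no measured pair shows this exact exchange, so the direction of the step is open, and the two heavier compounds give no guide to it. Inhibition at this concentration for compound 4 is expected to stay near that of compound 1 or to rise a little, with the step of a number 8.6 percentage points higher from compound 1 to compound 4 (within the scatter) expected to sit at about the edge of the scatter. Compound 4 is therefore estimated at 45%, with a range from 25% to 68%.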

Compound 4, a percentage reported as inhibition, at one concentration (the size of the read-out at that concentration, not a potency): 65.9%
Compound 4: the middle estimate sits 20.9 percentage points below what was measured, and the stated range covers the measured number.
By their numbers in this assay, from the lowest: compound 1; then compounds 4, 3 and 2 (each within the scatter of the next).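

In this assay, among these compounds, putting chloro in place of methoxy on the aromatic carbon gives the first single-change step in this set, a move of a number 29.5 percentage points higher from compound 1 to compound 4 (beyond the scatter) with the rest of the molecule unchanged. This shows that the group at this place on the six-membered aromatic ring, meta to a large group, matters for the read-out, and that going from 3-methoxyphenyl to 3-chlorophenyl raises inhibition at the tested concentration rather than leaving it flat. Nothing available here explains why this exchange has that effect.

The compounds shown leave open whether this rise is particular to chloro or would also appear with another group at the same place, such as fluoro, methyl, trifluoromethyl or nitrile, or with a plain hydrogen there. They also leave open how far the two compounds differ in potency, since a reading at one concentration gives the size of the inhibition at that concentration and not a potency, and whether the same exchange would give a similar step on a different amine chain.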